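The source may hold more compounds than are shown below. What is called first, only, known or untested is meant among the compounds shown, and "the series" means these compounds.

Compound 1, `NC1=NC2(CCSCC2)N(OCCCOc2ccc(Cl)cc2)C(N)=N1`, gives 1100 nM in a functional assay on HepG2 cells (Homo sapiens) for antiproliferative activity, read by MTT assay, with a stated time of 72 h; on this read-out higher numbers stand for weaker inhibition and lower numbers for stronger inhibition.
Compound 2, `NC1=NC2(CCSCC2)N(OCCCOc2ccc(Br)cc2)C(N)=N1`, gives 1400 nM in this assay.
Compound 3, `CC(C)(C)c1ccc(OCCCON2C(N)=NC(N)=NC23CCSCC3)cc1`, gives 70 nM in this assay.

Compound 3 has the lowest number of the three, so it is the strongest inhibitor among them; its nearest neighbour is compound 1, and the gap a 16-fold lower number from compound 1 to compound 3 (1.20 log units; beyond the scatter) is well beyond the scatter, as is a 20-fold lower number from compound 2 to compound 3 (1.30 log units; beyond the scatter). The two halogen compounds, by contrast, sit close together: a 1.3-fold higher number from compound 1 to compound 2 (0.10 log units; within the scatter).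

Compound 4, `COc1ccc(OCCCON2C(N)=NC(N)=NC23CCSCC3)cc1`, is not yet measured. It differs from compound 3 in one place: methoxy in place of tert-butyl on an aromatic carbon. Within the data shown here, the steps that bear on this are the two that remove tert-butyl, namely a 16-fold lower number from compound 1 to compound 3 (1.20 log units; beyond the scatter) and a 20-fold lower number from compound 2 to compound 3 (1.30 log units; beyond the scatter), both read in reverse: each time tert-butyl was exchanged for a smaller group, the number rose strongly. Methoxy is a small group as well, so a large rise in this assay is expected for compound 4, though no measured step with methoxy itself exists here. The expected step is an 11-fold higher number from compound 3 to compound 4 (1.06 log units; beyond the scatter), giving an estimate for compound 4 of 800 nM, with a range from 250 nM to 3000 nM.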

Compound 4, half-maximal inhibitory concentration: 880 nM
Estimate against measurement, compound 4: 1.1-fold (0.04 log units) below; the range from low to high includes it.
By their numbers in this assay, from the lowest: compound 3; then compounds 4, 1 and 2 (each within the scatter of the next).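

In this assay, the step of a 13-fold higher number from compound 3 to compound 4 (1.10 log units; beyond the scatter) shows that replacing tert-butyl at this place loses as much with an oxygen-bearing group as it does with a halogen, so the earlier drop was not particular to chloro or bromo. Methoxy also shows no separation from either halogen, with a 1.6-fold lower number from compound 2 to compound 4 (0.20 log units; within the scatter) and a 1.3-fold lower number from compound 1 to compound 4 (0.10 log units; within the scatter) both within the scatter, so among the four groups shown only tert-butyl stands apart. Nothing measured here explains why tert-butyl differs from the other three groups.

The compounds shown leave open whether a branched group such as isopropyl, or a ring such as cyclohexyl, would come near compound 3 at 70 nM, or whether tert-butyl alone gives such a low number. From the compounds shown here alone, how an amine or a carboxylic acid at this place would behave also remains open.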